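This account rests on a few compounds, and the source may have more. Where it says the series, first, only, none or still open, it means among the compounds named here.

Measured so far in a functional assay on HepG2 cells (Homo sapiens) for inhibition, read by MTT assay, with a stated time of 72 h (a higher number here means a weaker inhibitor, a lower number a stronger inhibitor), are three compounds:

- compound 1 `C=C(c1ccc(OC)c(F)c1)C1COC(C)(C)OO1` gives > 100000 nM as a limit of the assay
- compound 2 `C=C(c1ccc(OC)c(F)c1)C1COC2(CCCC2)OO1` gives 29300 nM as a measured number
- compound 3 `C=C(c1ccc(Cl)c(Cl)c1)C1COC(C)(C)OO1` gives > 100000 nM as a limit of the assay

Compound 2 is the only one of the three with an actual number. Going by the values given here, the other two entries are limits and not numbers (the limit of > 100000 nM in this assay, at which 2 of the 3 values shown sit), so there is no measured step to set beside it.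

Compound 4 `C=C(c1ccc(F)c(F)c1)C1COC2(CCCC2)OO1` keeps the rest of compound 2 and changes one group: fluoro in place of methoxy on an aromatic carbon, ortho to a fluoro group and para to a large group (fluoro in place of methoxy on an aromatic carbon).

Among the compounds with values here, no pair of measured compounds shows what such a swap does in this assay and the size of the step cannot be read from the data. With compound 2 at 29300 nM as the only anchor, no shift beyond the usual scatter is expected in either direction, although the uncertainty is wide. The expected change is small (a 1.0-fold higher number from compound 2 to compound 4 (0.01 log units; within the scatter)) on this reasoning. For compound 4 the estimated half-maximal inhibitory concentration is 30000 nM with an expected range from 12000 nM to 90000 nM in this assay.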

Compound 4, half-maximal inhibitory concentration: 38600 nM
Compound 4: the middle estimate sits 1.3-fold (0.11 log units) below what was measured; measured number inside the range.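

In this assay, going by these compounds alone, the only step between two real numbers is the swap of methoxy for fluoro on an aromatic carbon, ortho to a fluoro group and para to a large group, and it gives a 1.3-fold higher number from compound 2 to compound 4 (0.12 log units; within the scatter). For this pair, then, the hydrogen-bond acceptor of the methoxy group and the larger size of that group can be given up at this position with no change beyond the usual scatter, so neither compound can be ranked above the other. No other step can be read, because the remaining values are limits of the assay and not numbers: the limit of > 100000 nM in this assay, at which 2 of the 4 values shown sit.

The compounds shown leave open whether a different group at this same position, such as an amine, a carboxylic acid or a longer chain like butoxy, would move the number beyond the scatter. Within the data shown here, they also leave open whether the same swap would stay this quiet on a different core, such as the core of compound 1, where no pair with a measured number on both sides is available.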